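A few compounds are considered here, and "the series" means these few. Any claim that something is new, unique, unknown or untested is made for them only; others in the source may bear on it.

Measured compounds:
- compound 1, `O=S(=O)(NCCCNCc1ccccc1Cl)c1cc(C(F)(F)F)cc(C(F)(F)F)c1`: in a functional assay on Capan-2 cells (Homo sapiens) for inhibition, read by MTT assay, with a stated time of 72 h (a lower number here means a stronger inhibitor of growth, a higher number a weaker inhibitor of growth), compound 1 gives 13000 nM
- compound 2, `O=S(=O)(NCCCNCC1COc2ccccc2O1)c1cc(C(F)(F)F)cc(C(F)(F)F)c1`: in this assay compound 2 gives 2500 nM
- compound 3, `O=S(=O)(NCCCNCc1ccc(C(F)(F)F)cc1)c1cc(C(F)(F)F)cc(C(F)(F)F)c1`: in this assay compound 3 gives 2000 nM

Compound 1 stands highest of the three numbers in this assay; its nearest neighbour is compound 2, a 5.2-fold lower number from compound 1 to compound 2 (0.72 log units; beyond the scatter), and its furthest is compound 3, a 6.5-fold lower number from compound 1 to compound 3 (0.81 log units; beyond the scatter). Compound 2 and compound 3 sit close together, a 1.3-fold lower number from compound 2 to compound 3 (0.10 log units; within the scatter).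

The next compound, compound 4, `COc1ccccc1CNCCCNS(=O)(=O)c1cc(C(F)(F)F)cc(C(F)(F)F)c1`, differs from compound 1 by methoxy in place of chloro on an aromatic carbon. Among the measured compounds shown here, no measured step changes a single group on the 2-chlorophenyl ring in this way; the two steps from compound 1 swap the whole 2-chlorophenyl for another ring and both lower the number modestly. They bear only loosely on the methoxy-for-chloro change, so in this assay the expected step from compound 1 to compound 4 is a small lowering of the number, or none beyond the scatter, a 1.9-fold lower number from compound 1 to compound 4 (0.27 log units; within the scatter). Compound 4 is therefore estimated at 7000 nM, with a range from 2500 nM to 20000 nM.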

Compound 4, concentration for 50% growth inhibition: 6000 nM
Compound 4: the middle estimate sits 1.2-fold (0.07 log units) above what was measured, within the range that was stated.
By their numbers in this assay, from the lowest: compounds 3 and 2 (each within the scatter of the next); then compound 4; then compound 1.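

In this assay, changing one group on the aromatic carbon ortho to a large group, with the rest of compound 1 intact, gives a 2.2-fold lower number from compound 1 to compound 4 (0.34 log units; beyond the scatter); the number at this position therefore responds to a single-group change as well as to replacing the whole ring. The methoxy change covers only part of the ground gained by the whole-ring replacements, as shown by a 3.0-fold higher number from compound 3 to compound 4 (0.48 log units; beyond the scatter) and by a 2.4-fold higher number from compound 2 to compound 4 (0.38 log units; beyond the scatter). No measurement available here explains these steps.

Going by these compounds, it remains open whether a hydroxy, fluoro or nitrile group on the same aromatic carbon would give a number like that of methoxy or chloro. Also open, on these data alone, is whether the methoxy step would hold with a longer chain between the sulfonamide and the amine nitrogen.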